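Adding Methoxycarbonyl to a Biphenyl Choline Kinase Inhibitor

A few compounds are considered here, and "the series" means these few. Any claim that something is new, unique, unknown or untested is made for them only; others in the source may bear on it.

Compound 1 `CN1CCCN(Cc2ccc(-c3ccc(CN4CCCN(C)CC4)c(Cl)c3)cc2)CC1`: 268 nM
Compound 2 `CN1CCCN(Cc2ccc(-c3ccccc3)cc2)CC1`: 1480 nM

In an assay on isolated protein for inhibition of choline kinase alpha (Homo sapiens), with a stated time of 30 min (on this read-out higher numbers stand for weaker inhibition and lower numbers for stronger inhibition), compound 2 gives 1480 nM, the highest of the two numbers; compound 1 gives 268 nM, a gap beyond the scatter. Compound 3 `COC(=O)c1ccc(-c2ccc(CN3CCCN(C)CC3)cc2)cc1` has not been measured. It differs from compound 2 by methoxycarbonyl in place of hydrogen on an aromatic carbon. Going by the values given here, no measured step shows the effect of this change. A modest shift in either direction, most likely none beyond the scatter, is expected, so compound 3 is estimated at 1200 nM, between 400 nM and 3600 nM. The expected step is a 1.2-fold lower number from compound 2 to compound 3 (0.09 log units; within the scatter).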

Compound 3, half-maximal inhibitory concentration: 4950 nM
The estimate for compound 3 lay 4.1-fold (0.62 log units) below the measured number; measured number outside the range, above it.
By their numbers in this assay, from the lowest: compound 1; then compound 2; then compound 3.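

In this assay, methoxycarbonyl in place of hydrogen on an aromatic carbon, para to a large group, gives a 3.3-fold higher number from compound 2 to compound 3 (0.52 log units; beyond the scatter) and so shows that this position is not indifferent to substitution. Going by these compounds alone, it is the first reading at this place, and here the change weakens inhibition. No data shown here account for this shift. On these data alone, whether a carboxylic acid, an amine or a methyl group at the same place would move the number the same way remains open, as does the effect of methoxycarbonyl on the core of compound 1.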